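Aminomethyl triazole series: expectation for compound 4

The source may hold more compounds than are shown below. What is called first, only, known or untested is meant among the compounds shown, and "the series" means these compounds.

Measured so far in an assay on isolated protein with metabotropic glutamate receptor 1 (Homo sapiens) as the target; a lower number here means that less compound is needed, a higher number that more compound is needed for the effect:
compound 1 `CN(C)Cc1cn(CC(=O)Nc2sc3c(c2C(N)=O)CCCC3)nc1C(C)(C)C`: 316 nM
compound 2 `CC(C)NCc1cn(CC(=O)Nc2sc3c(c2C(N)=O)CCCC3)nc1C(F)(F)F`: 3160 nM
compound 3 `CN(C)Cc1cn(CC(=O)Nc2sc3c(c2C(N)=O)CCCC3)nc1C(F)(F)F`: 501 nM

Compound 1 and compound 3 lie within the scatter of each other, as a 1.6-fold higher number from compound 1 to compound 3 (0.20 log units; within the scatter) shows; compound 2 stands well apart with the higher number. Compound 4 `CCNCc1cn(CC(=O)Nc2sc3c(c2C(N)=O)CCCC3)nc1C(C)(C)C` is not yet measured; it differs from compound 1 by ethylamino in place of dimethylamino on a saturated chain carbon bound to an aromatic carbon. Going by the values given here, one measured step bears on that change: a 6.3-fold lower number from compound 2 to compound 3 (0.80 log units; beyond the scatter), where the compound carrying isopropylamino had the higher number. Compound 4 brings in an amino group with a hydrogen-bond donor once more, so an upward step in this assay is expected, though ethylamino and isopropylamino are not the same and nothing measured separates them. For compound 4 the expected step is a 3.2-fold higher number from compound 1 to compound 4 (0.50 log units; beyond the scatter). Compound 4 is estimated at 1000 nM, range 400 nM to 2500 nM.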

Compound 4, half-maximal effective concentration: 794 nM
Compound 4: middle estimate off by 1.3-fold (0.10 log units), on the high side; low and high end bracket the measured number.
By their numbers in this assay, from the lowest: compounds 1, 3 and 4 (each within the scatter of the next, the first and the last beyond it); then compound 2.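

In this assay, ethylamino in place of dimethylamino gives a 2.5-fold higher number from compound 1 to compound 4 (0.40 log units; beyond the scatter), so the higher number seen with a hydrogen-bond donor on the amine in a 6.3-fold lower number from compound 2 to compound 3 (0.80 log units; beyond the scatter) now also appears with tert-butyl in place of trifluoromethyl. The two groups hold the same atoms joined differently, and that rearrangement alone moves the number beyond the scatter. Nothing shown gives a reason for this step.

Ethylamino and isopropylamino sit in compounds with different partner groups, so the two remain unseparated. On these data alone, how a primary aminomethyl group or a pyrrolidine on this saturated chain carbon would read remains open.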